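The compounds below may be only part of what the source reports. "The series", "measured", "known", "first", "only" and "open" are said of these compounds alone.

Measured so far, all in a functional assay on NCI-H460 cells (Homo sapiens) for inhibition, read by MTT assay, with a stated time of 24 h, tested at 100 ug/mL; on this read-out higher numbers stand for more inhibition of growth at the one concentration tested and lower numbers for less inhibition of growth
compound 1 `O=C(O)CCCCC(CCSC(=O)c1ccccc1)SC(=O)c1ccccc1` gives 72.8%
compound 2 `O=C(CCCCC1CCSS1)Nc1ccc(Br)cn1` gives 52%
compound 3 `CC(=O)SCCC(CCCCC(=O)Nc1cccc(Cl)c1)SC(C)=O` gives 42.8%

Compound 1 has the highest number of the three in this assay, and both other compounds lie below it by more than the usual scatter. It ends in a free carboxy group, and the next compound to be tested changes exactly that end.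

Compound 4 `O=C(CCCCC(CCSC(=O)c1ccccc1)SC(=O)c1ccccc1)Nc1ccccc1` keeps the rest of compound 1 and has anilino in place of hydroxy on a carbonyl carbon. In other words, carboxy becomes phenylcarbamoyl.

Among the compounds with values here, no measured pair shows this change on its own, so the expectation rests on thin evidence. Compound 2 (52%) and compound 3 (42.8%) also lack carboxy and carry an amide instead, and both sit lower than compound 1, but they differ from it in other places too. They therefore hint at a direction without fixing a size.

A moderate fall is expected (a number 17.8 percentage points lower from compound 1 to compound 4 (beyond the scatter)), probably beyond the scatter, though with real uncertainty. Compound 4 is estimated at 55% (expected range 37% to 73%).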

Compound 4, percent growth inhibition at one concentration: "not active" (no number reported)
Nothing numeric was reported for compound 4; the estimate stays without a comparison.
By their numbers in this assay, from the lowest: compounds 3 and 2 (each within the scatter of the next); then compound 1.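

Within the data shown here, compound 4 is reported only as not active, without a number, so no step from compound 1 to compound 4 can be read. The compounds shown leave open how large the change is when carboxy becomes phenylcarbamoyl on the core of compound 1. Nothing measured here offers an explanation for this result.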